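The compounds below may be only part of what the source reports. "The series", "measured", "known", "first", "only" and "open" are said of these compounds alone.

Compound 1, `Fc1ccc(-c2nc3cnc(Nc4ccccn4)cc3[nH]2)cc1C(F)(F)F`, gives 64% in an ADME assay on microsomes from liver (Mus musculus) for metabolic stability, read by LC-MS, with a stated time of 30 min, tested at 0.1 uM; a lower number here means that less of the compound is left, a higher number that more of the compound is left.
Compound 2, `Fc1ccc(-c2nc3cnc(Nc4ccccn4)cc3[nH]2)cc1F`, gives 7.5%.
Compound 3, `FC1(F)CCC(c2nc3cnc(Nc4ccc(C(F)(F)F)cn4)cc3[nH]2)CC1`, gives 73%.

Compounds 1 and 2 share a core and differ in one place: fluoro in place of trifluoromethyl on an aromatic carbon. That change made the step of a number 56.5 percentage points lower from compound 1 to compound 2 (beyond the scatter). Compound 3 differs from compound 1 in more than one place; the difference between the two cores is not broken down here. Of the three measured numbers, that of compound 3 is the highest, but its gap to compound 1 lies within the scatter, so no order between those two is claimed; only compound 2 lies beyond the scatter from it.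

Compound 4, `Fc1ccc(Nc2cc3[nH]c(C4CCC(F)(F)CC4)nc3cn2)nc1`, is not yet measured in this assay. It differs from compound 3 in one place: fluoro in place of trifluoromethyl on an aromatic carbon. Among the compounds with values here, this is the same kind of change as the one from compound 1 to compound 2, but the surroundings are not the same: in the earlier pair the carbon sits in a six-membered aromatic ring of carbon only, ortho to a fluoro group and meta to a large group, whereas here it sits in a six-membered aromatic ring with 1 nitrogen, two atoms from the ring nitrogen, para to a large group. The expectation therefore rests on a single earlier example. Because the step of a number 56.5 percentage points lower from compound 1 to compound 2 (beyond the scatter) was large, the expected step for compound 4 is a number 48 percentage points lower from compound 3 to compound 4 (beyond the scatter), with a wide range to allow for the different surroundings. The estimate for compound 4 is 25%, between 5% and 55%.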

Compound 4, percent of the compound remaining in the Mus musculus assay: 91%
Compound 4: middle estimate off by 66 percentage points, on the low side; the measured number lies above the stated range.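

In the Mus musculus assay, compound 3 gives 73%, compound 4 gives 91%, and the same replacement of trifluoromethyl by fluoro now gives a number 18 percentage points higher from compound 3 to compound 4 (beyond the scatter), so the direction seen on the core of compound 1 did not carry over to the core of compound 3, as the two steps set together show: the same change on two cores in the Mus musculus assay, a number 56.5 percentage points lower (beyond the scatter) from compound 1 to compound 2 and a number 18 percentage points higher (beyond the scatter) from compound 3 to compound 4, 74.5 percentage points apart, beyond the scatter of two such steps This shows that, among these four compounds, the result of this change depends on the core that carries it, and that the earlier step alone could not be used to read off the later one. It does not show which difference between the two cores is responsible, whether the ring carrying the group or some other part, and two pairs give no rule for the series; in a physicochemical assay for solubility, using the shake flask method, in simulated intestinal fluid, measured as kinetic solubility, with a stated time of 20 h, at pH 6.5 (on this read-out lower numbers stand for lower solubility and higher numbers for higher solubility), compound 3 gives 93000 nM and compound 4 gives 170000 nM, and this one available pair gives a 1.8-fold higher number from compound 3 to compound 4 (0.26 log units; within the scatter), so no difference between compound 3 and compound 4 is claimed on that read-out.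

The compounds shown leave open how a chloro, nitrile or methoxy group would behave in the same place on the core of compound 3. They also leave open which direction the replacement of trifluoromethyl by fluoro would take on a third core.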